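The compounds below may be only part of what the source reports. "The series", "measured", "known", "first", "only" and "open" are said of these compounds alone.

Measured so far in an assay on a protein complex for inhibition of CDK8/Cyclin C (Homo sapiens), with a stated time of 1 h, tested at 10 uM; on this read-out higher numbers stand for more inhibition at the one concentration tested (going by the name of the read-out) and lower numbers for less inhibition:

compound 1, `CNC(=O)/C=C/c1ccncc1-c1ccc2ccccc2c1`, gives 101%
compound 2, `CN(C)C(=O)/C=C/c1ccncc1-c1ccc2ccccc2c1`, gives 100%
compound 3, `CNC(=O)COc1ccncc1-c1ccc2ccccc2c1`, gives 4%

Compound 3 stands lowest of the three, with a number 97 percentage points lower from compound 1 to compound 3 (beyond the scatter) and a number 96 percentage points lower from compound 2 to compound 3 (beyond the scatter), whereas a number 1 percentage points lower from compound 1 to compound 2 (within the scatter) shows that methylation of the amide nitrogen changes little. Compound 4, `COC(=O)CCc1ccncc1-c1ccc2ccccc2c1`, is not yet measured. Change: 2-(methoxycarbonyl)ethyl in place of (methylcarbamoyl)methoxy on an aromatic carbon. Going by the values given here, the group that enters brings back a chain attached through carbon, as in compound 1 and compound 2, but saturated and with an ester in place of the amide; no measured step covers either of those points. Both large steps bear on the change, and a rise in this assay is expected, though an uncertain one. For compound 4 the estimate is 40%, range 5% to 85%, meaning an expected a number 36 percentage points higher from compound 3 to compound 4 (beyond the scatter).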

Compound 4, a percentage reported as inhibition, at one concentration (the size of the read-out at that concentration, not a potency): 98%
For compound 4 the middle estimate is 58 percentage points below the measured one, outside the stated range (above it).
By their numbers in this assay, from the lowest: compound 3; then compounds 4, 2 and 1 (each within the scatter of the next).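

In this assay, 2-(methoxycarbonyl)ethyl on this aromatic carbon, opposite the ring nitrogen, reverses the loss seen with (methylcarbamoyl)methoxy: a number 94 percentage points higher from compound 3 to compound 4 (beyond the scatter). The ester chain, saturated and without a hydrogen-bond donor, stands level with both unsaturated amides, a number 2 percentage points lower from compound 2 to compound 4 (within the scatter) and a number 3 percentage points lower from compound 1 to compound 4 (within the scatter), so neither the ethenyl link nor the amide is needed for this read-out. No evidence available explains these steps.

The compounds shown do not separate the oxygen link in compound 3 from its amide, a question that (methoxycarbonyl)methoxy and 2-(methylcarbamoyl)ethyl groups would bear on. As far as these compounds go, how a carboxylic acid in place of the ester or a longer chain would read also stays open.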